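The compounds below may be only part of what the source reports. "The series", "measured", "known", "first", "only" and "open" are said of these compounds alone.

Measured compounds:
Compound 1 `Cc1ccc(S(=O)(=O)N2CCN(C[C@H](C)Nc3ncnc4c(C)csc34)CC2)cc1`: 170 nM
Compound 2 `Cc1noc(-c2ccccc2)c1NC(=O)OC(C)c1ccccc1`: > 50000 nM

In a functional assay on RH7777 cells for antagonist activity at lysophosphatidic acid receptor 2 (Homo sapiens), read by calcium flux (a lower number here means a stronger inhibitor, a higher number a weaker inhibitor), compound 1 gives 170 nM, and this is the only plain number shown for the series. Compound 2 gives only a limit of the assay, > 50000 nM, so its potency is not known beyond that bound; (the limit of > 50000 nM in this assay, at which 1 of the 2 values shown sits). Compound 1 therefore stands alone as the single measured point on the scale.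

Compound 3 `Cc1cccc(S(=O)(=O)N2CCN(C[C@H](C)Nc3ncnc4c(C)csc34)CC2)c1` differs from compound 1 by 3-methylphenyl in place of 4-methylphenyl on a sulfonyl sulfur. The two have the same atoms, joined differently, so the change is a shift of where the methyl sits on the ring attached to the sulfonyl sulfur. Within the data shown here, no step between measured compounds is recorded, so the size of this change is not yet fixed by anything seen here. The step from compound 1 to compound 3 is expected to be a 1.5-fold higher number from compound 1 to compound 3 (0.17 log units; within the scatter), that is, nothing clearly beyond the usual scatter. Compound 3 is therefore expected to give about 250 nM, within a range of 80 nM to 900 nM.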

Compound 3, half-maximal inhibitory concentration: 310 nM
The estimate for compound 3 lay 1.2-fold (0.09 log units) below the measured number, within the range that was stated.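

In this assay, shifting the methyl from 4-methylphenyl to 3-methylphenyl on the sulfonyl sulfur comes to a 1.8-fold higher number from compound 1 to compound 3 (0.26 log units; within the scatter), so these two placements cannot be told apart. Among these compounds, this is the first direct reading at this position: before it, compound 1 was the only plain number, with nothing to compare it against in a single change. Nothing measured here speaks to why the two compounds read alike.

The compounds shown leave open whether the methyl contributes anything at all, a question that plain phenyl on the sulfonyl sulfur would address. They also leave open whether a different group on this ring, such as methoxy, chlorine, a carboxylic acid or an amine, would produce a step beyond the scatter, as the two placements of methyl here do not.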